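The compounds below may be only part of what the source reports. "The series", "measured", "known", "first", "only" and "open" are said of these compounds alone.

Compound 1 `CCCCCCCCCCc1cc2cn(COCCO)c(O)nc-2n1` is the starting point. In a functional assay on HEL cells (Homo sapiens) (a lower number here means that less compound is tolerated, a higher number that more compound is tolerated), compound 1 gives 32000 nM. Compound 3 `CCCCCCCCCCCc1cc2cn(COCCO)c(O)nc-2n1` differs from it by methyl in place of hydrogen on a saturated chain carbon, ten or more bonds along the chain from an aromatic carbon, and in this assay compound 3 gives 41000 nM. The step between them is a 1.3-fold higher number from compound 1 to compound 3 (0.11 log units; within the scatter), so the two values cannot be told apart. Compound 2 `CCCCCCCC#Cc1cc2cn(COCCO)c(=O)nc2o1` is built on another core, and the difference between the two cores is not broken down here. In this assay compound 2 gives > 50000 nM, which is a limit of the assay and not a number. That reading is the limit of > 50000 nM in this assay, at which 1 of the 3 values shown sits. Compound 4 `CCCCCCCCC#Cc1cc2cn(COCCO)c(=O)nc2o1` has not yet been measured; it differs from compound 2 by methyl in place of hydrogen on a saturated chain carbon, seven bonds along the chain from a triple-bonded carbon. For the measured compounds named here, this is the same kind of change as the one between compound 1 and compound 3, though the place along the chain differs, as the two differences just given show. Going by the values given here, the only measured step of this kind is a 1.3-fold higher number from compound 1 to compound 3 (0.11 log units; within the scatter). On that basis the expected step is a step that the limit leaves unreadable from compound 2 to compound 4, again small. Compound 4 is therefore estimated at 55000 nM, most likely once more reported only as a limit of the assay.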

Compound 4, half-maximal cytotoxic concentration: 42000 nM
The estimate for compound 4 lay 1.3-fold (0.12 log units) above the measured number; the range from low to high includes it.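

In this assay the new step reads an at least 1.1-fold lower number from compound 2 to compound 4 (0.07 log units; that floor lies within the scatter). Compound 2 stands at a limit of the assay and not at a number: the limit of > 50000 nM in this assay, at which 1 of the 4 values shown sits.

The step on the core of compound 1 is within the scatter and the step on the core of compound 4 has only a floor, so this pair shows neither that the change carries over from one core to the other unaltered nor that the two cores respond differently, and the change also sits at a different place along the chain on each core: the same change on two cores in this assay, a 1.3-fold higher number (0.11 log units; within the scatter) from compound 1 to compound 3 and an at least 1.1-fold lower number (0.07 log units; that floor lies within the scatter) from compound 2 to compound 4; the limit leaves it open whether they differ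

The compounds shown leave open how the number would respond to a much shorter chain, or to an amine or a carboxylic acid at the end of the chain on either core. They also leave open how the two cores compare when they carry the same saturated chain.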